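The compounds below may be only part of what the source reports. "The series", "measured", "known", "first", "only" and "open" are said of these compounds alone.

Compound 3 `COc1cc(Oc2cccc(Nc3ccccc3)c2)cc(OC)c1CNC(C)C` is known in a functional assay on HCT-15 cells (Homo sapiens) for inhibition, read by MTT assay, with a stated time of 72 h (a higher number here means a weaker inhibitor, a lower number a stronger inhibitor), only as a limit, > 20000 nM, so no number stands for it. For the measured compounds named here, compound 2 `CNCc1c(OC)cc(Oc2cccc(Nc3ccccc3)c2)cc1OC` gives 8930 nM in this assay, and the one step that touches compound 3, an at least 2.2-fold higher number from compound 2 to compound 3 (0.35 log units; beyond the scatter), is the only measured change on the amine nitrogen; it is the step that lands on (the limit of > 20000 nM in this assay, at which 1 of the 3 values shown sits). Going by the values given here, compound 1 `COc1ccc(CCCNCc2c(OC)cc(Oc3ccc(Nc4ccccc4)cc3)cc2OC)cc1` gives 2180 nM in this assay; it carries the same 3-(4-methoxyphenyl)propyl group as the unmeasured compound 4 `COc1ccc(CCCNCc2c(OC)cc(Oc3cccc(Nc4ccccc4)c3)cc2OC)cc1`, but its shared core differs elsewhere, so no step connects it to compound 4. The change from compound 3 to compound 4 is 3-(4-methoxyphenyl)propyl in place of isopropyl on an amine nitrogen, on the amine nitrogen whose other neighbour is a saturated chain carbon. Compound 3 sits at a limit, so the step of an at least 5.0-fold lower number from compound 3 to compound 4 (0.69 log units; beyond the scatter) can only be estimated from that lower end. A lower number is expected because compound 1 gives 2180 nM with that group. In this assay compound 4 is estimated at 4000 nM, within 1200 nM to 15000 nM.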

Compound 4, half-maximal inhibitory concentration: 730 nM
For compound 4 the middle estimate is 5.5-fold (0.74 log units) above the measured one; measured number below the stated range.
By their numbers in this assay, from the lowest: compound 4; then compound 1; then compound 2. At a limit, above all of these: compound 3.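

For the compounds shown here, on the amine nitrogen, the earlier compounds showed only a loss in this assay on replacing methyl with isopropyl, an at least 2.2-fold higher number from compound 2 to compound 3 (0.35 log units; beyond the scatter). The 3-(4-methoxyphenyl)propyl group moves the number the other way at this same nitrogen, with a 12-fold lower number from compound 2 to compound 4 (1.09 log units; beyond the scatter), so a larger group here does not always weaken inhibition, and compound 3 is the one that goes against the gain. Against isopropyl the same change gives an at least 27-fold lower number from compound 3 to compound 4 (1.43 log units; beyond the scatter), but that size is only a bound, as the value of compound 3 is a limit and not a number: the limit of > 20000 nM in this assay, at which 1 of the 4 values shown sits.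

Going by these compounds alone, compound 1 gives 2180 nM with the same group on a core that differs elsewhere, and no step ties it to compound 4, so the effect of that core difference stays open. Also open, going by these compounds, is whether the gain depends on the methoxy group or on the chain, as a benzyl group, a longer chain or an unsubstituted 3-phenylpropyl group on this nitrogen would show.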